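From Compound 3 to Compound 4: a Shorter Amide Arm

The source may hold more compounds than are shown below. What is called first, only, known or untested is meant among the compounds shown, and "the series" means these compounds.

Measured compounds:
- Compound 1 `O=C(Nc1cccc(-n2cc(-c3ccncc3)c(-c3ccc(Cl)c(O)c3)n2)c1)Nc1ccc(Cl)c(Cl)c1` gives 1030 nM in a functional assay on SK-MEL-2 cells (Homo sapiens) for inhibition, read by sulforhodamine B assay, with a stated time of 48 h; on this read-out lower numbers stand for stronger inhibition of growth and higher numbers for weaker inhibition of growth.
- Compound 2 `COc1cc(-c2nn(-c3cccc(NC(=O)c4ccc(Cl)c(C(F)(F)F)c4)c3)cc2-c2ccncc2)ccc1Cl` gives 1900 nM in this assay.
- Compound 3 `COc1cc(-c2nn(-c3cccc(NC(=O)Nc4cccc(C(F)(F)F)c4)c3)cc2-c2ccncc2)ccc1Cl` gives 970 nM in this assay.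

Compound 3 carries the lowest of the three numbers, yet its neighbours sit close: compound 1 is within the scatter of it, and compound 2 lies a 2.0-fold lower number from compound 2 to compound 3 (0.29 log units; within the scatter), also within the scatter. On these three values nothing separates the compounds beyond the usual spread of repeated measurements.

Compound 4 `COc1cc(-c2nn(-c3cccc(NC(=O)c4ccccc4)c3)cc2-c2ccncc2)ccc1Cl` has not yet been measured. It differs from compound 3 at the carbonyl carbon: phenyl in place of (3-(trifluoromethyl)phenyl)amino on a carbonyl carbon. For the measured compounds named here, the one step that bears on this change is the one from compound 2 to compound 3, where a 4-chloro-3-(trifluoromethyl)phenyl on the carbonyl carbon gave way to a (3-(trifluoromethyl)phenyl)amino, and that step stayed within the scatter. Compound 4 goes further, keeping neither the amino link nor any trifluoromethyl, so the account cannot lean on a measured step of the same kind. It is therefore expected that compound 4 returns a somewhat higher number than compound 3, a step of a 2.6-fold higher number from compound 3 to compound 4 (0.41 log units; beyond the scatter), though a result within the scatter would not surprise. Compound 4 is estimated at 2500 nM, within a range from 1000 nM to 7000 nM.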

Compound 4, concentration for 50% growth inhibition: 389 nM
Estimate against measurement, compound 4: 6.4-fold (0.81 log units) above; the whole stated range lies above it.
By their numbers in this assay, from the lowest: compound 4; then compounds 3, 1 and 2 (each within the scatter of the next).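

In this assay the carbonyl carbon on the amide-type nitrogen becomes the first place where a single change moves the number beyond the scatter, with a 2.5-fold lower number from compound 3 to compound 4 (0.40 log units; beyond the scatter) as phenyl replaces (3-(trifluoromethyl)phenyl)amino. Phenyl also gives a lower number against 4-chloro-3-(trifluoromethyl)phenyl at this place, with a 4.9-fold lower number from compound 2 to compound 4 (0.69 log units; beyond the scatter) on a step that is likewise modest, whereas the step between the two substituted groups stayed within the scatter. Nothing measured here accounts for the fall in the number at this position.

The compounds shown leave open whether the lower number goes with the phenyl itself, with the loss of the trifluoromethyl or with the loss of the amino link, as compound 4 differs from compound 3 in both of these at once. A phenyl carrying a single fluorine or a methoxy, a plain phenylamino on the same carbonyl carbon, or a cyclohexyl or short alkyl chain there would each separate these readings, and how far the lower number extends beyond a plain phenyl remains untested among the compounds shown.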